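Extending the triazole side chain: compound 3 to compound 4

The source may report more compounds than this note shows. Statements on the series, on what has been measured and on what is new or still open speak of the compounds shown alone.

Compound 3 `C/C1=C\CC[C@@]2(C)O[C@@H]2[C@H]2OC(=O)[C@@H](Cn3cc(CO)nn3)[C@@H]2CC1` carries a 4-(hydroxymethyl)-1H-1,2,3-triazol-1-yl group on the shared core and stands at the weak end of the three values shown. In a functional assay on HL60/A cells (Homo sapiens) for cytotoxicity, read by flow cytometry and annexin V staining, with a stated time of 18 h (on this read-out higher numbers stand for weaker inhibition and lower numbers for stronger inhibition), compound 3 gives only a limit, > 100000 nM, at the limit of > 100000 nM in this assay, at which 1 of the 3 values shown sits. Its azido parent compound 2 `C/C1=C\CC[C@@]2(C)O[C@@H]2[C@H]2OC(=O)[C@@H](CN=[N+]=[N-])[C@@H]2CC1` gives 5900 nM in this assay. The step of an at least 16-fold higher number from compound 2 to compound 3 (1.22 log units; beyond the scatter) is the only measured one that touches this part of the molecule. Among the measured compounds shown here, compound 1 `CCCCC/C=C/C=C/C(=O)N1CCCC1` also gives a limit, > 50000 nM, at the limit of > 50000 nM in this assay, at which 1 of the 3 values shown sits, and has no single-point step to the others. Compound 4 `C/C1=C\CC[C@@]2(C)O[C@@H]2[C@H]2OC(=O)[C@@H](Cn3cc(CCCCO)nn3)[C@@H]2CC1` differs from compound 3 by 3-hydroxypropyl in place of hydroxy on a saturated chain carbon bound to an aromatic carbon. For the measured compounds named here, no measured step covers this change; the loss from compound 2 to compound 3 shows only that the azido-to-triazole exchange already takes the number to the limit, and says nothing about the length of the hydroxyalkyl chain. Compound 4 is therefore expected to remain at or near the limit in this assay, with the step of a number no higher from compound 3 to compound 4 (the limit leaves the size open) expected to be none beyond the scatter. The estimate for compound 4 is 100000 nM, ranging from 30000 nM to 300000 nM.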

Compound 4, half-maximal inhibitory concentration: > 100000 nM
Compound 4: a limit, no number; the forecaster's own chance of this, stated with the estimate: 75%; the middle value lies on the limit itself.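

Compound 3 and compound 4 both give only a limit in this assay, so no step between them can be read: the limit of > 100000 nM in this assay, at which 2 of the 4 values shown sit.

The compounds shown leave open whether going from hydroxymethyl to 4-hydroxybutyl on the triazole changes the activity in either direction.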